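The source may hold more compounds than are shown below. What is called first, only, known or untested is meant among the compounds shown, and "the series" means these compounds.

Measured so far:
compound 1, `COc1cc(/C=C/C(=O)c2cccc(-n3cc(-c4ccc(Cl)cc4)[nH]c3=O)c2)cc(OC)c1OC`: 3110 nM
compound 2, `COc1cc(/C=C/C(=O)c2cccc(-n3cc(-c4ccccc4)[nH]c3=O)c2)ccc1O`: 2040 nM

Both compounds were tested in a functional assay on OVCAR-5 cells (Homo sapiens) for inhibition; on this read-out lower numbers stand for stronger inhibition of growth and higher numbers for weaker inhibition of growth. Among the measured compounds shown here, compound 2 gives the smaller number of the two, but the only neighbour, compound 1, sits within the scatter of repeated measurements of this kind, so the two values cannot be placed in a meaningful order on this read-out.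

Compound 3, `O=C(/C=C/c1cccc(O)c1)c1cccc(-n2cc(-c3ccccc3)[nH]c2=O)c1`, has not yet been measured in this assay. It differs from compound 2 in one place: 3-hydroxyphenyl in place of 4-hydroxy-3-methoxyphenyl on a double-bonded chain carbon bound to a double-bonded chain carbon. For the measured compounds named here, no pair of measured compounds shows a change of this kind, so there is no measured step to draw on; the values of compound 1 and compound 2 say nothing about such an exchange.

With that gap in the data, the step from compound 2 to compound 3 is expected to be a 1.5-fold higher number from compound 2 to compound 3 (0.17 log units; within the scatter), a small shift toward a higher number that may well stay inside the scatter. Compound 3 is therefore estimated at 3000 nM, with a plausible range from 1000 nM to 9000 nM.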

Compound 3, concentration for 50% growth inhibition: 5440 nM
Beside the measured number, compound 3's estimate is 1.8-fold (0.26 log units) below it, and the stated range covers the measured number.
By their numbers in this assay, from the lowest: compounds 2, 1 and 3 (each within the scatter of the next, the first and the last beyond it).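

Among the compounds shown here, the exchange of 4-hydroxy-3-methoxyphenyl for 3-hydroxyphenyl on a double-bonded chain carbon bound to a double-bonded chain carbon gives the first readable step in this assay. This step, a 2.7-fold higher number from compound 2 to compound 3 (0.43 log units; beyond the scatter), shows that the group at this position can shift the result toward weaker inhibition of growth, although only modestly. Both groups hold one six-membered aromatic ring of carbon only and 1 hydrogen-bond donor, but a single exchange of the whole group cannot show which part of it carries the difference, and no supporting data bear on the result.

The compounds shown leave open whether an amine or a carboxylic acid in place of the hydroxy group of 3-hydroxyphenyl would change the number in this assay, and in which direction. For the compounds shown here, they also leave open whether the same exchange would give a similar step on the core of compound 1, since no pair of compounds shows this change on that core.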